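Trifluoromethyl in Place of Fluoro: An Expected Step

The source may report more compounds than this note shows. Statements on the series, on what has been measured and on what is new or still open speak of the compounds shown alone.

Compound 2 `Oc1ccc(-c2cc(-c3ccc(F)cc3)cc(-c3cccc(O)c3)n2)cc1` stands alone as the compound with a numerical result in a functional assay on DU-145 cells (Homo sapiens) for inhibition; on this read-out higher numbers stand for weaker inhibition and lower numbers for stronger inhibition; in that assay compound 2 gives 15200 nM. Compound 1 `Oc1ccc(-c2cc(-c3ccc(F)cc3)cc(-c3ccccc3O)n2)cc1` has only a limit in this assay, namely > 50000 nM. That boundary is the limit of > 50000 nM in this assay, at which 1 of the 2 values shown sits, so compound 1 carries no number of its own. Among the measured compounds shown here, the single measured step, an at least 3.2-fold lower number from compound 1 to compound 2 (0.51 log units; beyond the scatter), concerns the hydroxyphenyl group on the shared core and says nothing about the other aromatic ring.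

Compound 3 `Oc1ccc(-c2cc(-c3ccc(C(F)(F)F)cc3)cc(-c3cccc(O)c3)n2)cc1` differs from compound 2 at exactly that other ring: trifluoromethyl in place of fluoro on an aromatic carbon. For the measured compounds named here, none of the measured steps touches this position, and none involves a trifluoromethyl group anywhere, so the record gives no direction for the change. With nothing to point one way or the other, the expected step of a 1.0-fold lower number from compound 2 to compound 3 (0.01 log units; within the scatter) is taken to be none beyond the scatter, though the range is left wide. Compound 3 is therefore estimated at 15000 nM in this assay, with a range from 5000 nM to 45000 nM.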

Compound 3, half-maximal inhibitory concentration: > 50000 nM
Compound 3: only a limit was reported; the forecaster's own chance of this, stated with the estimate: 20%; middle value at least 3.3-fold (0.52 log units) away from the limit.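

Trifluoromethyl in place of fluoro is the first change at this ring to be measured, and in this assay it goes toward weaker inhibition, with an at least 3.2-fold higher number from compound 2 to compound 3 (0.51 log units; beyond the scatter). Among the compounds shown here, the earlier step concerned only the hydroxyphenyl group, so this is the first sign that the read-out also responds to the group on the other aromatic ring, para to a large group, and that going from 4-fluorophenyl to 4-(trifluoromethyl)phenyl is not a neutral exchange here. The size of the step is only a lower bound, and compound 2 is now the only compound of the three with a number of its own: the limit of > 50000 nM in this assay, at which 2 of the 3 values shown sit.

As far as these compounds go, what an amine, a methoxy group or a carboxylic acid would do at this place remains open, as does the effect of a plain phenyl ring with no group there at all. Also open, from the compounds shown here alone, are how far past the limit compound 3 really lies and whether the same exchange would act in the same direction with the hydroxyl group placed differently on the other hydroxyphenyl ring of the shared core.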